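Chloro in Place of Bromo: Expecting the Tolerance of Compound 4

A few compounds are considered here, and "the series" means these few. Any claim that something is new, unique, unknown or untested is made for them only; others in the source may bear on it.

Compound 1 `Nc1ncnn2c([C@@H]3O[C@H](CO)C[C@H]3O)cc(-c3ccc(Cl)cc3)c12` — in this study compound 1 gives 24000 nM
Compound 2 `Nc1ncnc2c([C@@H]3O[C@H](CO)[C@@H](O)[C@H]3O)cn(-c3ccc(Br)cc3)c12` — compound 2 gives > 64000 nM, a limit of the assay
Compound 3 `Nc1ncnn2c([C@@H]3O[C@H](CO)[C@@H](O)[C@H]3O)cc(Br)c12` — compound 3 gives 2000 nM

The values come from an ADME assay on cells (Macrophage, Mus musculus) for cytotoxicity; a lower number here means that less compound is tolerated, a higher number that more compound is tolerated. Compound 1 gives 24000 nM and compound 3 gives 2000 nM in this assay. For compound 2 the readout is > 64000 nM, which is a limit of the assay and not a number. Compound 2 therefore stands at the limit of > 64000 nM in this assay, at which 1 of the 3 values shown sits, the top of the measured range. Going by the values given here, no two of the measured compounds differ in one place, so no measured step describes any single change.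

Compound 4 `Nc1ncnc2c([C@@H]3O[C@H](CO)[C@@H](O)[C@H]3O)cn(-c3ccc(Cl)cc3)c12` has not yet been measured in this assay. Compound 4 differs from compound 2 by chloro in place of bromo on an aromatic carbon, chloro taking the place of bromo on the aromatic carbon of the six-membered ring of carbon only, para to a large group.

For a change of this size, no step beyond the usual scatter is expected in this assay; the step of a number no higher from compound 2 to compound 4 (the limit leaves the size open) is expected to lie within that scatter. Compound 4 is thus estimated at 64000 nM, with an expected range from 32000 nM to 128000 nM, and a limit rather than a number is the likelier outcome.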

Compound 4, half-maximal cytotoxic concentration: > 64000 nM
Compound 4 ended at the assay's limit; the forecaster's own chance of this, stated with the estimate: 65%; the middle value lies on the limit itself.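

In this assay compound 4 gives > 64000 nM, a limit of the assay and not a number. Compound 2 stands at the same limit, so no step can be read between compound 2 and compound 4: the limit of > 64000 nM in this assay, at which 2 of the 4 values shown sit.

The compounds shown leave open whether the change from 4-bromophenyl to 4-chlorophenyl alters tolerance at all.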